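The source may hold more compounds than are shown below. What is called first, only, known or untested is meant among the compounds shown, and "the series" means these compounds.

Three measured compounds share one core; the variation sits on a saturated chain carbon bound to a nitrogen on an aromatic ring. Compound 1 `Oc1ccc(CNc2cc(C(F)(F)F)cc3[nH]ncc23)cc1` carries 4-hydroxyphenyl there, and in an assay for inhibition of Indoleamine 2,3-dioxygenase 1 (Homo sapiens), with stated times of 10 min and 60 min, tested at 10 uM (a lower number here means a weaker effect, a higher number a stronger effect of the compound at the concentration tested), compound 1 gives 37%. Compound 2 `CNC(=O)c1cccc(CNc2cc(C(F)(F)F)cc3[nH]ncc23)c1` carries a differently substituted phenyl ring, and in this assay compound 2 gives 33%. Compound 3 `FC(F)(F)c1cc(NCC2CNC2)c2cn[nH]c2c1` carries azetidin-3-yl, and in this assay compound 3 gives 10%, the lowest of the three numbers: the nearest, that of compound 2, and the furthest, that of compound 1, both lie beyond the scatter above it.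

Compound 4 `FC(F)(F)c1cc(NCc2cccc(Br)c2)c2cn[nH]c2c1` differs from compound 3 in one place: 3-bromophenyl in place of azetidin-3-yl on a saturated chain carbon bound to a nitrogen on an aromatic ring. Going by the values given here, the one measured step bearing on this exchange is a number 27 percentage points lower from compound 1 to compound 3 (beyond the scatter), which went from an aromatic ring to azetidin-3-yl and lost inhibition. Going back from azetidin-3-yl to an aromatic ring is expected to regain a similar amount, a rise of a number 22 percentage points higher from compound 3 to compound 4 (beyond the scatter). Compound 4 is thus estimated to give 32%, within a range from 15% to 50%.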

Compound 4, a percentage reported as inhibition, at one concentration (the size of the read-out at that concentration, not a potency): 23%
Compound 4: the middle estimate sits 9 percentage points above what was measured, and the stated range covers the measured number.
By their numbers in this assay, from the lowest: compound 3; then compounds 4, 2 and 1 (each within the scatter of the next, the first and the last beyond it).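

In this assay, a six-membered aromatic ring with no hydrogen-bond donor or acceptor still does better than azetidin-3-yl, with a number 13 percentage points higher from compound 3 to compound 4 (beyond the scatter) for this exchange, so the ring alone recovers part of what azetidin-3-yl lost. It does not recover all of it: 3-bromophenyl in place of 4-hydroxyphenyl gives a number 14 percentage points lower from compound 1 to compound 4 (beyond the scatter) on this scale, while bromo in place of methylcarbamoyl gives a number 10 percentage points lower from compound 2 to compound 4 (within the scatter) and leaves those two compounds indistinguishable. Nothing measured here explains why these groups differ.

On these data alone, whether an amine or a carboxylic acid in place of bromo on the aromatic ring would bring the number closer to that of compound 1 remains open. So does the effect of a longer chain on the saturated chain carbon.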